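Thiadiazole amide in place of anilide on the shared core

The source may report more compounds than this note shows. Statements on the series, on what has been measured and on what is new or still open speak of the compounds shown alone.

Measured so far:
compound 1 `CC(C)C(C(N)=O)c1ccc(Cl)cc1`: > 100000 nM
compound 2 `CC(C)[C@H](C(=O)Nc1ccccc1)c1ccc(Cl)cc1`: > 100000 nM

Neither measured compound yields a number in a functional assay on CHO cells for agonist activity at Free fatty acid receptor 2 (Homo sapiens), read by cAMP accumulation; on this read-out higher numbers stand for weaker inhibition and lower numbers for stronger inhibition. For compound 2 the entry > 100000 nM is a limit of the assay and not a measured value. Compound 1 likewise returns only a limit, > 100000 nM. Going by the values given here, compound 2 thus stands at the limit of > 100000 nM in this assay, at which 2 of the 2 values shown sit, together with the only other value in hand, so nothing on the numbers separates it from compound 1, and no measured step exists.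

Compound 3 `CC(C)[C@H](C(=O)Nc1nncs1)c1ccc(Cl)cc1` keeps the core of compound 2 and alters only the substituent on the amide nitrogen: 1,3,4-thiadiazol-2-yl in place of phenyl on an amide-type nitrogen. Among the compounds with values here, no measured pair shows how this exchange moves the read-out here, so the expectation rests on the change alone. The expected step is an at least 20-fold lower number from compound 2 to compound 3 (1.30 log units; beyond the scatter), towards stronger inhibition and beyond the usual scatter, while a further limit stays possible. Compound 3 is accordingly estimated at 5000 nM, with a range from 500 nM to 100000 nM.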

Compound 3, half-maximal inhibitory concentration: 12000 nM
Compound 3: the middle estimate sits 2.4-fold (0.38 log units) below what was measured, within the range that was stated.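

In this assay, 1,3,4-thiadiazol-2-yl in place of phenyl on the amide-type nitrogen gives an at least 8.3-fold lower number from compound 2 to compound 3 (0.92 log units; beyond the scatter), so the substituent at this nitrogen can move the read-out on the shared core, which compound 1 and compound 2 could not show; the size printed is a bound and not a measured distance. The exchange alters several things at once: a six-membered aromatic ring of carbon only leaves, and a five-membered aromatic ring with 3 hetero atoms and 3 hydrogen-bond acceptors enters, so this single pair cannot assign the step to any one of these features. Compound 3 holds the only value in the set that is a number, and it gives the series a measured reference point, while the other two compounds remain at one assay limit: the limit of > 100000 nM in this assay, at which 2 of the 3 values shown sit.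

Open, from the compounds shown here alone, is whether a 1,3-thiazol-2-yl or a pyridin-2-yl group on the same nitrogen would keep the step, which would begin to separate ring size from the hetero atoms. Also open, going by these compounds, is whether a methyl or an amino group added to the 1,3,4-thiadiazol-2-yl ring would lower the number further in this assay.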